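Working notes: chloro in place of iodo

The source may hold more compounds than are shown below. What is called first, only, known or untested is meant among the compounds shown, and "the series" means these compounds.

Of the compounds shown here, three have numbers so far in a functional assay on HeLa cells (Homo sapiens) for cytotoxicity, read by MTT assay, with a stated time of 48 h; on this read-out higher numbers stand for weaker inhibition and lower numbers for stronger inhibition. Compound 1 (`CC1(C)CCCC2=CC=C(C=O)CC[C@]21C`) gives 163000 nM, and compound 2 (`C#CC1=CC[C@]2(CC1)C(=C)CC[C@H]2C(C)C`) gives 97600 nM. Compound 3 (`C=C1CCC[C@]2(C)CCC(c3cn(-c4ccc(I)cc4)nn3)=CC[C@@]12C`) gives 144000 nM, which lies within the scatter of both other values, so the three cannot be ranked.

Compound 4 (`C=C1CCC[C@]2(C)CCC(c3cn(-c4ccc(Cl)cc4)nn3)=CC[C@@]12C`) has not yet been measured. It differs from compound 3 by chloro in place of iodo on an aromatic carbon, para to a large group: chloro in place of iodo on an aromatic carbon. Among the compounds with values here, no measured pair differs in one place, so the data offer no direct precedent for this change. Even so, compound 1 at 163000 nM and compound 2 at 97600 nM stay within the scatter of compound 3 despite their different structures, so no large move is expected in this assay. The expected result is a 1.1-fold lower number from compound 3 to compound 4 (0.04 log units; within the scatter), which is none beyond the scatter. For compound 4 the estimated value is 130000 nM, with an expected range of 70000 nM to 230000 nM.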

Compound 4, half-maximal inhibitory concentration: 18800 nM
Beside the measured number, compound 4's estimate is 6.9-fold (0.84 log units) above it; measured number outside the range, below it.
By their numbers in this assay, from the lowest: compound 4; then compounds 2, 3 and 1 (each within the scatter of the next).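

In this assay, within the data shown here, this position is not silent: chloro in place of iodo gives a 7.7-fold lower number from compound 3 to compound 4 (0.88 log units; beyond the scatter), the only step so far between compounds that differ in one place. The earlier compounds shown here differ from one another in more than one place, so they could not show that exchanging a single halogen on an aromatic carbon, para to a large group, can move this read-out beyond the scatter. No measurement at hand explains the step, so no cause can be assigned to it.

As far as these compounds go, one pair gives no trend across the halogens, so it remains open whether fluoro or bromo at the same place would follow this step or depart from it. From the compounds shown here alone, it also remains open whether a methoxy group or an amine there would keep the lower number.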